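This account rests on a few compounds, and the source may have more. Where it says the series, first, only, none or still open, it means among the compounds named here.

Measured so far, in a functional assay on NCI-H1975 cells (Homo sapiens) for inhibition, read by MTT assay, with a stated time of 72 h; a higher number here means a weaker inhibitor, a lower number a stronger inhibitor:
compound 1, `C=CC(=O)Nc1cccc(NC(=O)CSc2nc(Nc3ccccc3Cl)c3ccccc3n2)c1`, 10000 nM
compound 2, `C=CC(=O)Nc1cccc(NC(=O)CSc2nc(Nc3ccccc3C)c3ccccc3n2)c1`, 9920 nM
compound 3, `C=CC(=O)Nc1cccc(NC(=O)CSc2nc(Nc3cccc(C)c3)c3ccccc3n2)c1`, 12100 nM

Compound 3 stands among these three with no separation from either neighbour: the step of a 1.2-fold higher number from compound 1 to compound 3 (0.08 log units; within the scatter) and the step of a 1.2-fold higher number from compound 2 to compound 3 (0.09 log units; within the scatter) both lie within the scatter, as does a 1.0-fold lower number from compound 1 to compound 2 (0.00 log units; within the scatter), so the shared core has so far given one level of activity whatever the aryl group on the nitrogen.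

Compound 4, `C=CC(=O)Nc1cccc(NC(=O)CSc2nc(Nc3cccc(OC)c3)c3ccccc3n2)c1`, differs from compound 3 by methoxy in place of methyl on an aromatic carbon. The two steps that changed this aryl group bear on it, and neither moved the number beyond the scatter. The step of a 1.2-fold lower number from compound 3 to compound 4 (0.06 log units; within the scatter) is therefore expected to be flat, and compound 4 is estimated at 10500 nM, in the range 5000 nM to 22000 nM.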

Compound 4, half-maximal inhibitory concentration: 7940 nM
Beside the measured number, compound 4's estimate is 1.3-fold (0.12 log units) above it, and the stated range covers the measured number.
By their numbers in this assay, from the lowest: compounds 4, 2, 1 and 3 (each within the scatter of the next).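

Methoxy brings a hydrogen-bond acceptor that methyl lacks, yet on this ring it adds no separation in this assay (a 1.5-fold lower number from compound 3 to compound 4 (0.18 log units; within the scatter)). The 3-methoxyphenyl group also stays level with the 2-methylphenyl group (a 1.2-fold lower number from compound 2 to compound 4 (0.10 log units; within the scatter)) and the 2-chlorophenyl group (a 1.3-fold lower number from compound 1 to compound 4 (0.10 log units; within the scatter)), so the single level of activity now extends to an aryl group carrying an acceptor. No evidence at hand accounts for this. On these data alone, whether an amine, a carboxylic acid or a longer chain at this position would leave that level remains open.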